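A few compounds are considered here, and "the series" means these few. Any claim that something is new, unique, unknown or untested is made for them only; others in the source may bear on it.

Compound 1 `CCOC(=O)c1cc(/C=C/c2cccc(C(C)C)c2)on1`: > 128000 nM
Compound 2 `CCOC(=O)c1cc(/C=C/c2cccc(C)c2)on1`: > 128000 nM
Compound 3 `CCOC(=O)c1cc(/C=C/c2c(Cl)cncc2Cl)on1`: > 128000 nM

All three entries come from an ADME assay on Vero cells (Chlorocebus sabaeus) for cytotoxicity, with a stated time of 72 h (on this read-out higher numbers stand for weaker inhibition and lower numbers for stronger inhibition), and each is a limit of the assay, not a number: the limit of > 128000 nM in this assay, at which 3 of the 3 values shown sit. Compound 3 therefore stands only at its limit of > 128000 nM. Compound 4 `CCC(CC)OC(=O)c1cc(/C=C/c2c(Cl)cncc2Cl)on1` differs from compound 3 in one place, with pentan-3-yl in place of ethyl on an oxygen next to a carbonyl group. Among the measured compounds shown here, the only measured step, a step that the two limits leave unreadable from compound 1 to compound 2, changes a different place and offers no size to borrow. No step beyond the scatter is therefore expected, and the estimated step is a number no higher from compound 3 to compound 4 (the limit leaves the size open). For compound 4 the estimated value is 128000 nM, with an expected range from 60000 nM to 128000 nM.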

Compound 4, half-maximal inhibitory concentration: > 128000 nM
Compound 4 was reported as a limit; the forecaster's own chance of this, stated with the estimate: 80%; the middle value sits exactly at the limit.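

Compound 3 and compound 4 both stand at a limit of the assay, so no step can be read between them. The compounds shown leave open the true value of each in this assay: the limit of > 128000 nM in this assay, at which 4 of the 4 values shown sit.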